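This account rests on a few compounds, and the source may have more. Where it says the series, first, only, none or still open, it means among the compounds named here.

Measured so far in a functional assay on MDA-MB-231 cells (Homo sapiens) for cytotoxicity, read by MTT assay, with a stated time of 48 h; a higher number here means a weaker inhibitor, a lower number a stronger inhibitor:
Compound 1 `COC(=O)Cn1cc(CO[C@H]2CC(=O)[C@@H]3OC[C@H]2O3)nn1` gives 21300 nM.
Compound 2 `O=C1C[C@H](OCc2cn(-c3ccc(F)cc3)nn2)[C@H]2CO[C@@H]1O2` gives 23700 nM.

Compound 2 holds the higher of these two numbers, but its gap to compound 1 lies within the scatter, so the two cannot be told apart. Compound 3 `CCCCn1cc(CO[C@H]2CC(=O)[C@@H]3OC[C@H]2O3)nn1` differs from compound 2 by butyl in place of 4-fluorophenyl on an aromatic nitrogen. Among the compounds with values here, the single measured step at this same aromatic nitrogen, a 1.1-fold higher number from compound 1 to compound 2 (0.05 log units; within the scatter), exchanged quite different groups and still stayed within the scatter. On that basis the expected step of a 1.1-fold lower number from compound 2 to compound 3 (0.03 log units; within the scatter) is none beyond the scatter. Compound 3 is therefore estimated at 22000 nM in this assay, with a range from 8000 nM to 60000 nM.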

Compound 3, half-maximal inhibitory concentration: 27900 nM
The estimate for compound 3 lay 1.3-fold (0.10 log units) below the measured number, within the range that was stated.
By their numbers in this assay, from the lowest: compounds 1, 2 and 3 (each within the scatter of the next).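

In this assay, a ring-free chain on this aromatic nitrogen reads like the aryl group it replaces, with a 1.2-fold higher number from compound 2 to compound 3 (0.07 log units; within the scatter) for that exchange. Set against the (methoxycarbonyl)methyl group, butyl also gives only a 1.3-fold higher number from compound 1 to compound 3 (0.12 log units; within the scatter), so all three groups, with or without a ring, cannot be told apart here. No measurement on hand accounts for this.

Still open, from the compounds shown here alone, is whether any group on this nitrogen can move the number beyond the scatter. A longer chain, or a butyl chain ending in an amine or a carboxylic acid, would test this.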